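Pyridyl swap on the sulfonamide nitrogen

The compounds below may be only part of what the source reports. "The series", "measured", "known", "first", "only" and "open" are said of these compounds alone.

Compound 1 `CCc1ccccc1N(CC(=O)NCc1ccccc1F)S(=O)(=O)c1ccc(C)cc1` and compound 2 `Cc1ccc(S(=O)(=O)N(CC(=O)NCc2ccc(Cl)cc2)c2cccnc2C)cc1` differ in more than one place, so only their values are compared. In a functional assay on CHO-K1 cells for antagonist activity at prostaglandin E2 receptor EP1 subtype (Homo sapiens), read by FLIPR and calcium flux (a higher number here means a weaker inhibitor, a lower number a stronger inhibitor), compound 1 gives 135 nM, and compound 2 gives 676 nM, the highest of the two numbers and beyond the scatter from compound 1. Compound 3 `Cc1ccc(S(=O)(=O)N(CC(=O)NCc2ccc(Cl)cc2)c2ccc(C)cn2)cc1` is an untested rearrangement of compound 2: 5-methylpyridin-2-yl in place of 2-methylpyridin-3-yl on a sulfonamide nitrogen. Among the compounds with values here, with no measured step of this kind, a small rise, at most near the edge of the scatter, is expected for a 1.3-fold higher number from compound 2 to compound 3 (0.12 log units; within the scatter). Compound 3 is therefore estimated at 900 nM, range 250 nM to 3500 nM.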

Compound 3, inhibition constant: < 1450 nM
Compound 3: a limit, no number; the forecaster's own chance of this, stated with the estimate: 10%; the middle value lies beyond the limit too.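

Within the data shown here, compound 3 gives < 1450 nM, a limit and not a number, and no step from compound 2 to compound 3 can be read. Still open, going by these compounds, is how 5-methylpyridin-2-yl compares with 2-methylpyridin-3-yl on a sulfonamide nitrogen.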